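This account rests on a few compounds, and the source may have more. Where it says the series, first, only, none or still open, it means among the compounds named here.

Measured so far:
compound 1 `Cn1ccc2c(Oc3ccc(NC(=O)c4nn(-c5ccc(Br)cc5F)ccc4=O)cc3)ccnc21` — 31200 nM
compound 2 `Cn1ccc2c(Oc3ccc(NC(=O)c4nn(-c5ccccc5)ccc4=O)cc3F)ccnc21` — > 60000 nM

Notes on the series. In a functional assay on HepG2 cells (Homo sapiens) for cytotoxicity, read by MTT assay, with a stated time of 72 h (a lower number here means a stronger inhibitor, a higher number a weaker inhibitor), compound 1 gives 31200 nM. Compound 2 shows > 60000 nM in this assay, a limit of the assay and not a number. Compound 2 thus stands at the limit of > 60000 nM in this assay, at which 1 of the 2 values shown sits, so where it sits on the scale is not known. The next compound, compound 3 `Cn1ccc2c(Oc3ccc(NC(=O)c4nn(-c5ccc(Br)cc5F)ccc4=O)cc3F)ccnc21`, differs from compound 2 by 4-bromo-2-fluorophenyl in place of phenyl on an aromatic nitrogen; that is, 4-bromo-2-fluorophenyl in place of phenyl on an aromatic nitrogen. Among the measured compounds shown here, no measured pair covers this change directly. Compound 1 carries the same 4-bromo-2-fluorophenyl group and gives a number in this assay, so compound 3 is expected to land near that value or somewhat weaker, with a real chance of a limit. For compound 3 the estimate is 40000 nM, range 15000 nM to 120000 nM, which means an expected step of an at least 1.5-fold lower number from compound 2 to compound 3 (0.17 log units; that floor lies within the scatter).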

Compound 3, half-maximal inhibitory concentration: 24000 nM
Compound 3: the middle estimate sits 1.7-fold (0.22 log units) above what was measured; the range from low to high includes it.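

In this assay, 4-bromo-2-fluorophenyl in place of phenyl on an aromatic nitrogen gives an at least 2.5-fold lower number from compound 2 to compound 3 (0.39 log units; beyond the scatter). Compound 2 remains a limit of the assay and not a number, and the true size of this step is therefore unknown: the limit of > 60000 nM in this assay, at which 1 of the 3 values shown sits. Fluoro in place of hydrogen on an aromatic carbon gives a 1.3-fold lower number from compound 1 to compound 3 (0.11 log units; within the scatter), so with 4-bromo-2-fluorophenyl in place, this change does not separate the two compounds.

The compounds shown compare the 4-bromo-2-fluorophenyl group only as a whole, leaving open how much of the step belongs to the bromine and how much to the fluorine. Also open, going by these compounds, is how a phenyl ring carrying an amine or a carboxylic acid at this position would read in this assay.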